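The source may hold more compounds than are shown below. What is called first, only, known or untested is meant among the compounds shown, and "the series" means these compounds.

Measured compounds so far:

compound 1, `CCCCCC(=O)OCCc1ccc(O)cc1`, 166000 nM
compound 2, `CCCCCCCCCC(=O)OCCc1ccc(O)cc1`, 172000 nM
compound 3, `CCCCCCCC(=O)OCCc1ccc(O)c(O)c1`, 104000 nM

All three were run in a toxicity assay on MRC5 cells (Homo sapiens) for inhibition, read by MTT assay, with a stated time of 72 h; on this read-out higher numbers stand for weaker inhibition and lower numbers for stronger inhibition. Compound 1 and compound 2 share a core and differ by butyl in place of hydrogen on a saturated chain carbon, five bonds along the chain from a carbonyl carbon; the step that change made is a 1.0-fold higher number from compound 1 to compound 2 (0.02 log units; within the scatter), so lengthening the chain at that place left the read-out essentially where it was. Compound 3 carries a different core; the difference between the two cores is not broken down here. In this assay compound 3 gives 104000 nM, and this number sits within the scatter of the numbers of compound 1 and compound 2, so no order among the three can be claimed.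

Compound 4, `CCCCCCCCCCCC(=O)OCCc1ccc(O)c(O)c1`, has not yet been measured. It differs from compound 3 by butyl in place of hydrogen on a saturated chain carbon, seven bonds along the chain from a carbonyl carbon. This is the same kind of change as that from compound 1 to compound 2, but not the same: there the butyl enters five bonds along the chain from the carbonyl carbon, here seven bonds along. Since the earlier step, a 1.0-fold higher number from compound 1 to compound 2 (0.02 log units; within the scatter), was within the scatter, the step from compound 3 to compound 4 is expected to be of similar size, about a 1.1-fold higher number from compound 3 to compound 4 (0.02 log units; within the scatter). Compound 4 is accordingly estimated at 110000 nM, with a likely range from 55000 nM to 220000 nM; this rests only on the two measured pairs and on the value of compound 3, 104000 nM.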

Compound 4, half-maximal inhibitory concentration: 38100 nM
Estimate against measurement, compound 4: 2.9-fold (0.46 log units) above; the measured number lies below the stated range.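

In this assay, butyl in place of hydrogen on a saturated chain carbon, seven bonds along the chain from a carbonyl carbon, gives a 2.7-fold lower number from compound 3 to compound 4 (0.44 log units; beyond the scatter) and so a modest move towards stronger inhibition. This does not show that the core alone sets the size of the step, since the two pairs also differ in where the butyl enters, five bonds along the chain in one and seven in the other, and each case rests on a single pair. What the comparison does show is that the step seen on one core cannot be carried unchanged to the other in this series: the same change on two cores in this assay, a 1.0-fold higher number (0.02 log units; within the scatter) from compound 1 to compound 2 and a 2.7-fold lower number (0.44 log units; beyond the scatter) from compound 3 to compound 4, 2.8-fold (0.45 log units) apart, beyond the scatter of two such steps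

The compounds shown leave open whether a longer chain on the core of compound 3 would extend this step or leave the read-out flat. They also leave open whether a carboxylic acid or an amine in place of butyl at that chain carbon would give a step of similar size on either core.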